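The source may hold more compounds than are shown below. What is called first, only, known or untested is meant among the compounds shown, and "the series" means these compounds.

Measured in a functional assay on ECa-109 cells (Homo sapiens) for antiproliferative activity, read by MTT assay, with a stated time of 72 h; on this read-out lower numbers stand for stronger inhibition and higher numbers for weaker inhibition:
- compound 1 `C#CCSc1nc(N/N=C/c2ccc(N(C)C)cc2)c2nnn(Cc3ccccc3)c2n1`: 31300 nM
- compound 2 `C#CCSc1nc(N/N=C/c2c(O)ccc3ccccc23)c2nnn(Cc3ccccc3)c2n1`: 6520 nM
- compound 3 `CCCSc1nc(N/N=C/c2cc(OC)c(OC)c(OC)c2)c2nnn(Cc3ccccc3)c2n1`: 4060 nM

Compound 1 has the highest of these three numbers, which makes it the weakest inhibitor of the set. Compound 4 `CCCSc1nc(N/N=C/c2ccc(N(C)C)cc2)c2nnn(Cc3ccccc3)c2n1` is compound 1 with one change: ethyl in place of ethynyl on a saturated chain carbon bound to a sulfur. Put simply, ethyl stands in place of ethynyl, turning propargylsulfanyl into propylsulfanyl.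

Within the data shown here, no measured step isolates this swap. Among the measured compounds shown here, the only step available, a 4.8-fold lower number from compound 1 to compound 2 (0.68 log units; beyond the scatter), concerns a different group, the one on the carbon with a double bond to nitrogen. It shows how far a change there moved the number, but says nothing direct about the sulfur chain. Compound 3 carries propylsulfanyl too, at 4060 nM, yet it also differs from compound 4 in that other group.

With so little to go on, no change beyond the scatter is expected in this assay, perhaps a slightly lower number. The expected step is a 1.4-fold lower number from compound 1 to compound 4 (0.15 log units; within the scatter). For compound 4 the estimated value is 22000 nM, with an expected range of 8000 nM to 60000 nM.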

Compound 4, half-maximal inhibitory concentration: 20000 nM
The estimate for compound 4 lay 1.1-fold (0.04 log units) above the measured number; measured number inside the range.
By their numbers in this assay, from the lowest: compounds 3 and 2 (each within the scatter of the next); then compounds 4 and 1 (each within the scatter of the next).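

In this assay, among these compounds, the first step that isolates the sulfur chain is a 1.6-fold lower number from compound 1 to compound 4 (0.19 log units; within the scatter), with propylsulfanyl in place of propargylsulfanyl. This step lies within the scatter, so with the 4-(dimethylamino)phenyl group held constant, the triple bond can be lost without a clear change in the number. No available evidence explains this outcome.

Going by these compounds, compound 2 carries only propargylsulfanyl and compound 3 only propylsulfanyl, so it remains open whether the two chains also read alike with those other groups on the carbon with a double bond to nitrogen. Also open, on these data alone, is how a longer chain such as butylsulfanyl, or a chain ending in an amine, would compare with propylsulfanyl on the same core.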